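Swapping the anilino aryl group on a bromophenyl core

A few compounds are considered here, and "the series" means these few. Any claim that something is new, unique, unknown or untested is made for them only; others in the source may bear on it.

The series shares a common core, shown here in compound 3 `N#Cc1c(Nc2cccc(C(F)(F)F)c2)nc(SCc2cn(CC(=O)NC(=O)Nc3ccccn3)nn2)nc1-c1ccc(Br)cc1`. In a functional assay on MCF7 cells (Homo sapiens) for inhibition, read by MTT assay, with a stated time of 72 h (a lower number here means a stronger inhibitor, a higher number a weaker inhibitor), compound 3 gives 3110 nM, the lowest of the two numbers reported; its nearest neighbour is compound 1 `CC(C)c1ccc(Nc2nc(SCc3cn(CC(=O)NC(=O)Nc4ccccn4)nn3)nc(-c3ccc(C(C)C)cc3)c2C#N)cc1`, which in this assay gives 28600 nM. Compound 2 `Cc1ccc(-c2nc(SCc3cn(CC(=O)NC(=O)Nc4ccccn4)nn3)nc(Nc3ccc(C(C)C)cc3)c2C#N)cc1` reaches only a limit of the assay, > 64000 nM. Compound 4 `CC(C)c1ccc(Nc2nc(SCc3cn(CC(=O)NC(=O)Nc4ccccn4)nn3)nc(-c3ccc(Br)cc3)c2C#N)cc1` is not yet measured. It differs from compound 3 in one place: 4-isopropylphenyl in place of 3-(trifluoromethyl)phenyl on a nitrogen on an aromatic ring. Among the measured compounds shown here, none of the measured steps touches that position. For the measured compounds named here, the only single-point step, an at least 2.2-fold higher number from compound 1 to compound 2 (0.34 log units; beyond the scatter), concerns the other aryl group and ends at a limit (the limit of > 64000 nM in this assay, at which 1 of the 3 values shown sits), so it bears on the new change only as a sign that this scaffold can lose activity readily. Compound 1 carries the same 4-isopropylphenyl anilino group and sits well behind compound 3, but it also differs at the second aryl group, so its value cannot be read as a clean step. Compound 4 is therefore expected to give a higher number than compound 3, a step of a 3.9-fold higher number from compound 3 to compound 4 (0.59 log units; beyond the scatter), with an estimate in this assay of 12000 nM (range 4000 nM to 40000 nM).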

Compound 4, half-maximal inhibitory concentration: 30600 nM
Beside the measured number, compound 4's estimate is 2.6-fold (0.41 log units) below it; measured number inside the range.
By their numbers in this assay, from the lowest: compound 3; then compounds 1 and 4 (each within the scatter of the next). At a limit, above all of these: compound 2.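

In this assay, changing only the group on the nitrogen, with 4-isopropylphenyl in place of 3-(trifluoromethyl)phenyl, gives a 9.8-fold higher number from compound 3 to compound 4 (0.99 log units; beyond the scatter), so this position alone accounts for a step beyond the scatter. With 4-isopropylphenyl held on the nitrogen, bromo in place of isopropyl on the other aryl group gives a 1.1-fold higher number from compound 1 to compound 4 (0.03 log units; within the scatter), so that exchange does not separate the two compounds. Compound 2 stands at a limit of the assay, so bromo in place of methyl reads only as a bound, an at least 2.0-fold lower number from compound 2 to compound 4 (0.32 log units; beyond the scatter): the limit of > 64000 nM in this assay, at which 1 of the 4 values shown sits.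

Going by these compounds, how a plain phenyl or a 3-isopropylphenyl on that nitrogen would read remains open, so the step cannot yet be divided between the trifluoromethyl, the isopropyl and their ring positions. Also open, on these data alone, is whether 3-(trifluoromethyl)phenyl keeps its advantage with methyl or isopropyl on the other aryl group.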